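The source may report more compounds than this note shows. Statements on the series, on what has been measured and on what is new or still open speak of the compounds shown alone.

Among the measured compounds shown here, in a functional assay on HeLa cells (Homo sapiens) for antiproliferative activity, with a stated time of 5 days (on this read-out higher numbers stand for weaker inhibition and lower numbers for stronger inhibition), compound 1 `CC1OC2(C=CC(=O)C=C2)N(c2nc(-c3ccc4ccccc4c3)nn2-c2ccc3ccccc3c2)C1=O` gives 300 nM and compound 2 `Cc1ccc(-n2nc(-c3ccc4ccccc4c3)nc2N2C(=O)COC23C=CC(=O)C=C3)cc1` gives 150 nM as its value, so compound 2 stands within the usual scatter of the only other number available. For the measured compounds named here, compound 3 `O=C1C=CC2(C=C1)OCC(=O)N2c1nc(-c2ccc3ccccc3c2)nn1-c1ccc2ccccc2c1` carries naphthalen-2-yl in place of 4-methylphenyl on an aromatic nitrogen and has no measurement yet. Going by the values given here, no measured pair shows this change alone, so the expectation is cautious: no shift beyond the scatter in this assay for this swap. The estimated change is a 1.3-fold higher number from compound 2 to compound 3 (0.12 log units; within the scatter) only. For compound 3 the estimated value is 200 nM with an expected range from 80 nM to 500 nM overall.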

Compound 3, half-maximal inhibitory concentration: 210 nM
The estimate for compound 3 lay 1.1-fold (0.02 log units) below the measured number; the measured number falls inside the stated range.
By their numbers in this assay, from the lowest: compounds 2, 3 and 1 (each within the scatter of the next).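

In this assay putting naphthalen-2-yl in place of 4-methylphenyl on the aromatic nitrogen gives a 1.4-fold higher number from compound 2 to compound 3 (0.15 log units; within the scatter) and so does not separate these two aromatic groups at this position. Hydrogen in place of methyl on a saturated ring carbon gives a 1.4-fold lower number from compound 1 to compound 3 (0.15 log units; within the scatter) and so shows no measurable role for that methyl in this assay. Nothing available explains why these groups read alike. Still open, going by these compounds, is whether a plain butyl chain on that aromatic nitrogen, or an amine or carboxylic acid on its aromatic ring, would keep numbers in this range.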